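Compound 3 Before Measurement: A Chlorophenyl Urea

The source may hold more compounds than are shown below. What is called first, only, known or untested is meant among the compounds shown, and "the series" means these compounds.

The study measures growth inhibition in a functional assay on HGC-27 cells (Homo sapiens) for inhibition, read by MTT assay, with a stated time of 72 h; on this read-out lower numbers stand for stronger inhibition and higher numbers for weaker inhibition. Compound 1 `C=C[C@]1(C)C[C@@H](OC(=O)CNC(=O)Nc2ccc(OC)cc2)[C@]2(C)[C@H](C)CC[C@]3(CCC(=O)[C@H]32)[C@@H](C)[C@@H]1O` carries a 4-methoxyphenyl group on an amide-type nitrogen. In this assay compound 1 gives > 10000 nM, which is a limit of the assay rather than a number. Compound 2 `C=C[C@]1(C)C[C@@H](OC(=O)CNC(=O)NC(=O)c2cccc(F)c2)[C@]2(C)[C@H](C)CC[C@]3(CCC(=O)[C@H]32)[C@@H](C)[C@@H]1O` bears a (3-fluorophenyl)carbonyl in place of 4-methoxyphenyl on an amide-type nitrogen. In this assay compound 2 likewise reaches only a limit, > 10000 nM. The step that the two limits leave unreadable from compound 1 to compound 2 therefore cannot be read. Compound 2 stands at the limit of > 10000 nM in this assay, at which 2 of the 2 values shown sit, so its place among the numbers shown is known only as that limit. Compound 3 `C=C[C@]1(C)C[C@@H](OC(=O)CNC(=O)Nc2ccc(Cl)cc2)[C@]2(C)[C@H](C)CC[C@]3(CCC(=O)[C@H]32)[C@@H](C)[C@@H]1O` differs from compound 2 by 4-chlorophenyl in place of (3-fluorophenyl)carbonyl on an amide-type nitrogen. Only the unreadable step from compound 1 to compound 2 bears on this change, and it gives no size in either direction. Both measured compounds sit at the limit, so compound 3 is expected to remain there as well, and the expected step that the limit leaves unreadable from compound 2 to compound 3 is set accordingly. Compound 3 is estimated at 15000 nM, with a range from 5000 nM to 50000 nM.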

Compound 3, half-maximal inhibitory concentration: > 10000 nM
Compound 3: no number, only a limit (the forecaster's own chance of this, stated with the estimate: 80%); the middle value is on the limit's open side.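

In this assay compound 3 gives > 10000 nM, which is a limit and not a number. The steps to compound 3 from compound 1 and from compound 2 therefore cannot be read. The compounds shown leave open whether any group on the amide-type nitrogen can bring a measurable value in this read-out.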